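This account rests on a few compounds, and the source may have more. Where it says the series, first, only, none or still open, it means among the compounds named here.

Compound 1 `CCCCCCOc1ccc2c(Cl)ccnc2c1` is the starting point of this account. In a functional assay on SK-OV-3 cells (Homo sapiens) for cytotoxicity, read by MTT assay, with a stated time of 48 h (on this read-out higher numbers stand for weaker inhibition and lower numbers for stronger inhibition), compound 1 gives > 10000 nM, which is a limit of the assay rather than a number, so compound 1 stands at the weak end of what has been measured (the limit of > 10000 nM in this assay, at which 1 of the 2 values shown sits). Going by the values given here, compound 2 `CC(C)COc1ccc2c(Cl)ccnc2c1`, the only other measured compound, gives 3190 nM in this assay, and the step of an at least 3.1-fold lower number from compound 1 to compound 2 (0.49 log units; beyond the scatter) is the sole measured change in the set. Compound 3 `CCCCCCOc1ccc2c(NCCN(C)C)ccnc2c1` differs from compound 1 by (2-(dimethylamino)ethyl)amino in place of chloro on an aromatic carbon. Among the compounds with values here, the measured step concerns the chain on the aromatic oxygen and not this position, so no measured step bears directly on the change to compound 3. The direction and size of the step are therefore open. On the sparse numbers shown, compound 3 is estimated at 3000 nM in this assay, within a range from 400 nM to 12000 nM. This estimate means an expected step of an at least 3.3-fold lower number from compound 1 to compound 3 (0.52 log units; beyond the scatter).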

Compound 3, half-maximal inhibitory concentration: 1860 nM
The estimate for compound 3 lay 1.6-fold (0.21 log units) above the measured number, and the stated range covers the measured number.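

Going by these compounds alone, compound 3 brings the first measured change at the aromatic carbon opposite the ring nitrogen, whereas the earlier step touched only the chain on the aromatic oxygen. In this assay, (2-(dimethylamino)ethyl)amino in place of chloro gives an at least 5.3-fold lower number from compound 1 to compound 3 (0.73 log units; beyond the scatter), which shows that this position also affects the read-out while the chain on the oxygen stays as in compound 1. The value of compound 1 is a limit and not a number, so the size of this step is bounded on one side only: the limit of > 10000 nM in this assay, at which 1 of the 3 values shown sits.

The compounds shown do not tell whether the terminal dimethylamino, the amine hydrogen or the ethyl link matters most, and a morpholine or a longer chain at this position is not among them. As far as these compounds go, whether the same replacement would give a similar step on the chain of compound 2 also remains open.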